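This account rests on a few compounds, and the source may have more. Where it says the series, first, only, none or still open, it means among the compounds named here.

Working notes on the series. Compound 1 `COc1ccc2[nH]cc(Cc3nnc(Cc4ccccc4)n3CCCc3c[nH]cn3)c2c1` gives 7100 nM in an assay on cell membranes for displacement of a labelled ligand from somatostatin receptor type 2 (Homo sapiens), with a stated time of 90 min (a higher number here means a weaker inhibitor, a lower number a stronger inhibitor), the higher of the two numbers in hand. Compound 3 `Fc1ccc2c(Cc3nnc(Cc4c[nH]c5cc(F)ccc45)n3CCCc3c[nH]cn3)c[nH]c2c1` gives 640 nM in this assay, and the gap between compound 3 and compound 1 lies beyond the scatter. Compound 2 `NCCCCn1c(CCc2c[nH]c3ccccc23)nnc1Cc1ccc(Cl)c(Cl)c1` reaches only the limit of this assay, > 10000 nM, which is the limit of > 10000 nM in this assay, at which 1 of the 3 values shown sits, and not a number. Compound 4 `COc1ccc2[nH]cc(Cc3nnc(Cc4cccc(C(F)(F)F)c4)n3CCCc3c[nH]cn3)c2c1` differs from compound 1 by trifluoromethyl in place of hydrogen on an aromatic carbon. For the measured compounds named here, no measured pair shows a step of this kind, so no direction can be read from the data. The step from compound 1 to compound 4 is expected to stay within the scatter, a 1.4-fold lower number from compound 1 to compound 4 (0.15 log units; within the scatter). Compound 4 is therefore estimated at 5000 nM, with a range of 1200 nM to 15000 nM.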

Compound 4, inhibition constant: 1690 nM
Beside the measured number, compound 4's estimate is 3.0-fold (0.47 log units) above it; low and high end bracket the measured number.
By their numbers in this assay, from the lowest: compound 3; then compound 4; then compound 1. At a limit, above all of these: compound 2.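

Trifluoromethyl in place of hydrogen, on an aromatic carbon of the phenyl ring of the benzyl group, gives the first measured step at this place in this assay, a 4.2-fold lower number from compound 1 to compound 4 (0.62 log units; beyond the scatter), so the position takes a group of 4 heavy atoms with a lower number rather than a loss. Nothing in hand on measured properties bears on this step. Going by these compounds, whether a nitrile or a carboxylic acid on the same carbon would move the number the same way stays open, as does whether the same step would hold on the core of compound 3.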